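Removing a Large Side Arm: What to Expect for Compound 3

A few compounds are considered here, and "the series" means these few. Any claim that something is new, unique, unknown or untested is made for them only; others in the source may bear on it.

Measured so far:
Compound 1 `CCCCc1ccc(CN(Cc2ccccc2)C(C)=O)c(=O)n1Cc1ccc(-c2ccccc2-c2nn[nH]n2)cc1`: 1 nM
Compound 2 `CCCCc1ccc(CN(Cc2ccccc2)S(=O)(=O)c2ccccc2)c(=O)n1Cc1ccc(-c2ccccc2-c2nn[nH]n2)cc1`: 20 nM

Both compounds were examined in a functional assay (aorta) for antagonist activity, with Oryctolagus cuniculus as the target; on this read-out lower numbers stand for stronger inhibition and higher numbers for weaker inhibition. In this assay compound 1 gives 1 nM, the lowest of the two numbers. Compound 2 gives 20 nM. Within the data shown here, the one measured step, a 20-fold higher number from compound 1 to compound 2 (1.30 log units; beyond the scatter), shows that altering the group attached to the amine nitrogen within that side arm already costs a great deal of activity.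

Compound 3 `CCCCc1cccc(=O)n1Cc1ccc(-c2ccccc2-c2nn[nH]n2)cc1` differs from compound 1 by a larger change: hydrogen in place of (acetyl(benzyl)amino)methyl on an aromatic carbon. Among the measured compounds shown here, no measured step covers the removal of the whole arm, so the step from compound 1 to compound 2 is the only guide, and it points toward weaker inhibition. A loss at least as large as that step is therefore expected, with wide uncertainty. Compound 3 is expected to give 40 nM in this assay, with a likely range from 5 nM to 400 nM, a step of a 40-fold higher number from compound 1 to compound 3 (1.60 log units; beyond the scatter).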

Compound 3, half-maximal inhibitory concentration: 4 nM
The estimate for compound 3 lay 10-fold (1.00 log units) above the measured number, outside the stated range (below it).
By their numbers in this assay, from the lowest: compound 1; then compound 3; then compound 2.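

Replacing the whole (acetyl(benzyl)amino)methyl arm with hydrogen gives a 4.0-fold higher number from compound 1 to compound 3 (0.60 log units; beyond the scatter) in this assay, so this position keeps strong inhibition even with nothing larger than hydrogen on it. The arm adds something to the number, but the rest of the molecule carries most of the activity seen here. A change inside the arm, phenylsulfonyl in place of acetyl, gave a 20-fold higher number from compound 1 to compound 2 (1.30 log units; beyond the scatter), a larger step than losing the arm entirely, so an unfavourable group on the arm can cost more than having no arm at all. Nothing available here explains why these two steps differ in size.

Still open, as far as these compounds go, is whether a small group at this position, such as a methyl or a carboxylic acid, would behave more like hydrogen or like the full arm. A simple aminomethyl group would show whether the amine nitrogen alone recovers the difference.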